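Swapping a naphthalene for an ethylphenyl on a shared core

This account rests on a few compounds, and the source may have more. Where it says the series, first, only, none or still open, it means among the compounds named here.

Of the compounds shown here, two have been measured in a physicochemical assay for lipophilicity, using the shake flask method, in phosphate buffer, measured as octanol-water partition, with a stated time of 85 min, at pH 7.4; on this read-out lower numbers stand for lower lipophilicity and higher numbers for higher lipophilicity. Compound 1 `O=Cc1ccc(-c2cn3ccnc3c(-c3ccc4ncn(C5CCCCC5)c4c3)n2)cc1` gives 1.5 and compound 2 `c1ccc2c(-c3cn4ccnc4c(-c4ccc5ncn(C6CCCCC6)c5c4)n3)cccc2c1` gives 1.44, so compound 2 holds the lower of the two numbers, though the gap to compound 1 lies within the scatter. Within the data shown here, the one step measured so far, a number 0.06 log units lower from compound 1 to compound 2 (within the scatter), exchanged one flat aromatic group for another without moving the read-out beyond the scatter. Compound 3 `CCc1ccc(-c2cn3ccnc3c(-c3ccc4ncn(C5CCCCC5)c4c3)n2)cc1` differs from compound 2 by 4-ethylphenyl in place of naphthalen-1-yl on an aromatic carbon. Among the measured compounds shown here, this is again an exchange of one aromatic group of carbon only for another, with no change in donors, acceptors or charge, and the only comparable step, a number 0.06 log units lower from compound 1 to compound 2 (within the scatter), was flat. Compound 3 is therefore expected to sit close to compound 2, with a step of a number 0.01 log units higher from compound 2 to compound 3 (within the scatter) in this assay. Compound 3 is estimated at 1.45, within a range from 1.1 to 1.8.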

Compound 3, partition coefficient: 1.66
Compound 3: middle estimate off by 0.21 log units, on the low side; measured number inside the range.
By their numbers in this assay, from the lowest: compounds 2, 1 and 3 (each within the scatter of the next).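

In this assay the step of a number 0.22 log units higher from compound 2 to compound 3 (within the scatter) shows that 4-ethylphenyl, with one six-membered aromatic ring of carbon only, can stand at this aromatic carbon in place of the two rings of naphthalen-1-yl without the read-out leaving the scatter. Ethyl in place of formyl gives a number 0.16 log units higher from compound 1 to compound 3 (within the scatter) and adds a second exchange at the same place that stays inside the scatter, so the three groups shown here cannot be told apart by this read-out. Nothing available explains how these groups compare in this assay.

As far as these compounds go, whether an amine or a carboxylic acid at this aromatic carbon would move the read-out beyond the scatter remains open. The same question stands for a longer chain in place of ethyl.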